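The source may report more compounds than this note shows. Statements on the series, on what has been measured and on what is new or still open speak of the compounds shown alone.

Measured compounds:
compound 1, `COc1ccccc1C(=O)NC(=S)Nc1ccc(N2CCCCC2)c(Cl)c1`: 27 ug/mL
compound 2, `COc1ccccc1C(=O)NC(=O)Nc1ccc(-c2nccs2)c(C(F)(F)F)c1`: 12 ug/mL
compound 3, `COc1ccncc1C(=O)NC(=O)Nc1ccc(-c2ccccc2)c(C(F)(F)F)c1`: 16 ug/mL

In a physicochemical assay for solubility, in simulated intestinal fluid (on this read-out higher numbers stand for higher solubility and lower numbers for lower solubility), compound 2 gives the lowest of the three numbers. Its value and that of compound 3 lie within the scatter of each other, so nothing separates them; compound 1 gives a higher number, and that gap lies beyond the scatter. Compound 4, `COc1ccccc1C(=O)NC(=O)Nc1ccc(OCC(F)(F)F)c(C(F)(F)F)c1`, has not yet been measured. It differs from compound 2 in one place: 2,2,2-trifluoroethoxy in place of 1,3-thiazol-2-yl on an aromatic carbon. Within the data shown here, no step between two measured compounds isolates a change of this kind, so the expectation rests on compound 2 alone. In this assay the expected step is a 1.2-fold lower number from compound 2 to compound 4 (0.08 log units; within the scatter), small and with no direction beyond the scatter. Compound 4 is therefore expected to give about 10 ug/mL, between 4 ug/mL and 25 ug/mL.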

Compound 4, solubility: 2.2 ug/mL
Estimate against measurement, compound 4: 4.5-fold (0.66 log units) above; the whole stated range lies above it.
By their numbers in this assay, from the lowest: compound 4; then compounds 2, 3 and 1 (each within the scatter of the next, the first and the last beyond it).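

Through this assay, this position now has its first step: putting 2,2,2-trifluoroethoxy in place of 1,3-thiazol-2-yl, on the aromatic carbon ortho to a trifluoromethyl group, gives a 5.5-fold lower number from compound 2 to compound 4 (0.74 log units; beyond the scatter) between two compounds that differ nowhere else. The read-out at this position therefore depends on the group it carries, at least for this exchange of a ring for an open chain. Nothing shown accounts for the size of this step. As far as these compounds go, whether methoxy or an amine such as morpholin-4-yl on this carbon would give a number nearer that of compound 2 stays open.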